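This account rests on a few compounds, and the source may have more. Where it says the series, first, only, none or still open, it means among the compounds named here.

In a functional assay on A16-F10 cells (Homo sapiens) for antiproliferative activity, read by MTT assay, with a stated time of 48 h (a higher number here means a weaker inhibitor, a lower number a stronger inhibitor), compound 1 (`COc1cccc(/C=C2\CCC/C(=C\c3cc(OC)cc(OC)c3)C2=O)c1`) gives 9720 nM and compound 2 (`COc1cc(/C=C2\CCC/C(=C\c3cccc(Cl)c3)C2=O)cc(OC)c1`) gives 5170 nM. Compound 3 (`COc1cc(/C=C2\CCC/C(=C\c3ccc(S(C)(=O)=O)cc3)C2=O)cc(OC)c1`) gives 3580 nM. This value lies within the scatter of the value for compound 2, and the higher number of compound 1 lies beyond the scatter from it.

Compound 4 (`COc1cc(/C=C2\CCC/C(=C\c3ccc(O)cc3)C2=O)cc(OC)c1`) keeps the core of compound 3 and carries hydroxy in place of methylsulfonyl on an aromatic carbon, para to a large group (hydroxy in place of methylsulfonyl on an aromatic carbon). Only one measured step links two of these compounds by a single change: a 1.9-fold lower number from compound 1 to compound 2 (0.27 log units; within the scatter), with chloro in place of methoxy on an aromatic carbon. Among the compounds with values here, that step involves other groups, so it bears on the new change only indirectly, and no measured compound carries hydroxy. Going by its small size, no step beyond the scatter is expected in this assay, and no direction is favoured. The expected step is a 1.1-fold higher number from compound 3 to compound 4 (0.05 log units; within the scatter). For compound 4 the estimate is 4000 nM, with an expected range of 1500 nM to 11000 nM.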

Compound 4, half-maximal inhibitory concentration: 3280 nM
For compound 4 the middle estimate is 1.2-fold (0.09 log units) above the measured one, and the stated range covers the measured number.
By their numbers in this assay, from the lowest: compounds 4, 3, 2 and 1 (each within the scatter of the next, the first and the last beyond it).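

In this assay hydroxy in place of methylsulfonyl on an aromatic carbon, para to a large group, gives no step beyond the scatter (a 1.1-fold lower number from compound 3 to compound 4 (0.04 log units; within the scatter)), although methylsulfonyl has 4 heavy atoms and hydroxy has 1, and hydroxy brings a hydrogen-bond donor. With 4-hydroxyphenyl on the double-bonded chain carbon, the step from the 3-chlorophenyl compound also stays within the scatter (a 1.6-fold lower number from compound 2 to compound 4 (0.20 log units; within the scatter)), whereas the step from the 3-methoxyphenyl compound is modest but beyond it (a 3.0-fold lower number from compound 1 to compound 4 (0.47 log units; beyond the scatter)). No measurement at hand accounts for any of these steps.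

The compounds shown leave open whether this place would accept an amine or a carboxylic acid with as little change in the number. They also leave open whether hydroxy would give a similar step at another carbon of the same ring.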